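A few compounds are considered here, and "the series" means these few. Any claim that something is new, unique, unknown or untested is made for them only; others in the source may bear on it.

Measured compounds, read in a functional assay on DU-145 cells (Homo sapiens) for inhibition, read by trypan blue exclusion, with a stated time of 96 h; a higher number here means a weaker inhibitor of growth, a lower number a stronger inhibitor of growth:
compound 1 `Cc1ccc(CS/C(=C/c2c[nH]c3ccc(Br)cc23)C(=O)c2ccc(Cl)cc2)cc1` gives 1000 nM;
compound 2 `Cc1ccc(CS/C(=C/c2ccc(Br)cc2)C(=O)c2ccc(Cl)cc2)cc1` gives 10000 nM;
compound 3 `O=C(/C(=C\c1ccc(Br)cc1)SCc1ccc(F)cc1)c1ccc(Cl)cc1` gives 9000 nM.

Compound 1 and compound 2 share everything except the group on the double-bonded chain carbon: 5-bromo-1H-indol-3-yl in place of 4-bromophenyl on a double-bonded chain carbon bound to a double-bonded chain carbon. Among the measured compounds shown here, that change made a 10-fold lower number from compound 2 to compound 1 (1.00 log units; beyond the scatter), the one step in the set that stands beyond the scatter. Compound 2 and compound 3 differ only in the core: fluoro in place of methyl on an aromatic carbon. The matching step is a 1.1-fold lower number from compound 2 to compound 3 (0.05 log units; within the scatter), within the scatter, so on the cores of compound 2 and compound 3 the change from methyl to fluoro leaves this assay essentially unchanged.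

Compound 4 `O=C(/C(=C\c1c[nH]c2ccc(Br)cc12)SCc1ccc(F)cc1)c1ccc(Cl)cc1` is not yet measured. It stands to compound 3 as compound 1 stands to compound 2: 5-bromo-1H-indol-3-yl in place of 4-bromophenyl on a double-bonded chain carbon bound to a double-bonded chain carbon. The two place lines read the same word for word, so this is the same change, carried onto the fluoro-bearing core. The change has been seen once in the set, from compound 2 to compound 1, where it made a 10-fold lower number from compound 2 to compound 1 (1.00 log units; beyond the scatter). Because the core change a 1.1-fold lower number from compound 2 to compound 3 (0.05 log units; within the scatter) left the number where it was, the fluoro core of compound 3 and compound 4 is taken to behave like the methyl core of compound 2 and compound 1, and a step of the same size is expected for compound 4 as a 10-fold lower number from compound 3 to compound 4 (1.00 log units; beyond the scatter). That rests on one precedent only. Compound 4 is therefore estimated to give 900 nM in this assay, with a range from 400 nM to 2500 nM.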

Compound 4, concentration for 50% growth inhibition: 50000 nM
For compound 4 the middle estimate is 56-fold (1.74 log units) below the measured one; measured number outside the range, above it.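

In this assay, the exchange of 4-bromophenyl for 5-bromo-1H-indol-3-yl does not carry over from the methyl-bearing core to the fluoro-bearing core, where it gives a 5.6-fold higher number from compound 3 to compound 4 (0.74 log units; beyond the scatter), a step opposite in direction to the earlier one: the same change on two cores in this assay, a 10-fold lower number (1.00 log units; beyond the scatter) from compound 2 to compound 1 and a 5.6-fold higher number (0.74 log units; beyond the scatter) from compound 3 to compound 4, 56-fold (1.74 log units) apart, beyond the scatter of two such steps

Read the other way, fluoro in place of methyl has no effect beyond the scatter on the 4-bromophenyl pair, yet on the 5-bromo-1H-indol-3-yl pair it gives a 50-fold higher number from compound 1 to compound 4 (1.70 log units; beyond the scatter), so the two changes do not add independently across these four compounds: the same change on two cores in this assay, a 1.1-fold lower number (0.05 log units; within the scatter) from compound 2 to compound 3 and a 50-fold higher number (1.70 log units; beyond the scatter) from compound 1 to compound 4, 56-fold (1.74 log units) apart, beyond the scatter of two such steps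

This shows that the outcome of each change depends on the group present at the other place, but it rests on a single set of four compounds and does not show why the two changes interact or whether the reversal extends to any other member of the series.

On these data alone, it remains open whether another group on that aromatic carbon, such as methoxy or an amine, would follow the pattern of compound 1 or that of compound 4. As far as these compounds go, it also remains open whether the reversal needs the bromine of the 5-bromo-1H-indol-3-yl group, or would persist with a chloro or a methoxy group in its place.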